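A few compounds are considered here, and "the series" means these few. Any claim that something is new, unique, unknown or untested is made for them only; others in the source may bear on it.

Measured compounds:
- compound 1, `Cc1cc(C)c(NC(=O)N(Cc2cccc(-c3nnn(C)n3)c2)C2CCCCCC2)c(C)c1`: 100 nM
- compound 2, `O=C(Nc1c(F)cc(F)cc1F)N(Cc1cccc(-c2cc[nH]n2)c1)C1CCCCCC1`: 22 nM
- compound 3, `Cc1cc(C)c(NC(=O)N(Cc2ccc(-c3ccsc3)cc2)C2CCCCCC2)c(C)c1`: 19 nM

In an assay on microsomes from intestine for inhibition of acyl-CoA:cholesterol acyltransferase (Oryctolagus cuniculus) (on this read-out higher numbers stand for weaker inhibition and lower numbers for stronger inhibition), compound 1 stands with the highest of the three numbers. Compound 2 gives a number that lies well below it, and the gap is beyond the scatter; compound 3 gives the lowest number of the three, and its gap to compound 1 is also beyond the scatter. For the measured compounds named here, compounds 2 and 3 each differ from compound 1 in more than one place, so neither pair defines a single step, and what the two lower numbers share with each other is only that the five-membered aromatic ring on the benzyl group carries fewer hetero atoms than the ring in compound 1.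

Compound 4, `Cc1cc(C)c(NC(=O)N(Cc2cccc(-c3ccnn3C)c2)C2CCCCCC2)c(C)c1`, keeps the core of compound 1 and changes one thing: 1-methyl-1H-pyrazol-5-yl in place of 2-methyl-2H-tetrazol-5-yl on an aromatic carbon. Going by the values given here, no measured pair isolates this exchange. The pattern that both compounds 2 and 3, with rings of fewer hetero atoms, sit below compound 1 suggests a move in the same direction, tempered by the fact that those two compounds also differ from compound 1 elsewhere. For compound 4 a modest drop in the number is expected, a 2.0-fold lower number from compound 1 to compound 4 (0.30 log units; within the scatter), with the outcome estimated at 50 nM and a plausible range from 18 nM to 140 nM.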

Compound 4, half-maximal inhibitory concentration: 35 nM
Beside the measured number, compound 4's estimate is 1.4-fold (0.15 log units) above it; the range from low to high includes it.
By their numbers in this assay, from the lowest: compounds 3, 2 and 4 (each within the scatter of the next); then compound 1.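

For the compounds shown here, replacing 2-methyl-2H-tetrazol-5-yl with 1-methyl-1H-pyrazol-5-yl, on an aromatic carbon of a six-membered aromatic ring of carbon only, meta to a large group, gives in this assay a 2.9-fold lower number from compound 1 to compound 4 (0.46 log units; beyond the scatter), the first single-place step and one that lies beyond the scatter. The heavy-atom count, the five-membered aromatic ring, the absence of hydrogen-bond donors and the absence of net charge all stay the same, while a ring with 4 hetero atoms gives way to one with 2 hetero atoms, and the number at this position responds to an exchange of that kind. No measurement given here accounts for the size or direction of the step.

A single pair cannot show whether the step follows the count of hetero atoms or belongs to this particular ring, and a plain phenyl ring, a carboxylic acid or a dimethylamino group at this place would help to separate the two. Also open, from the compounds shown here alone, is whether the exchange gives a similar step when the rest of the molecule changes; compound 2 and compound 3 differ from compound 1 in more than one place and give no reading of this.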